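The source may report more compounds than this note shows. Statements on the series, on what has been measured and on what is new or still open speak of the compounds shown alone.

In a functional assay on NCI-H522 cells (Homo sapiens) for cytotoxicity, read by sulforhodamine B assay, with a stated time of 24 h (a higher number here means a weaker inhibitor of growth, a lower number a stronger inhibitor of growth), compound 2 `O=C(/C=C/c1cc2ccccc2[nH]c1=O)c1ccc(O)cc1` gives 3290 nM. Its closest neighbour in structure, compound 1 `COc1ccc(C(=O)/C=C/c2cc3ccccc3[nH]c2=O)cc1`, gives 6130 nM in this assay, and the two numbers sit within the usual scatter of each other, as a 1.9-fold lower number from compound 1 to compound 2 (0.27 log units; within the scatter) shows. Compound 3 `O=C(/C=C/c1cc2ccccc2[nH]c1=O)c1ccc(Cl)cc1` has not been measured; it differs from compound 2 by chloro in place of hydroxy on an aromatic carbon. For the measured compounds named here, the only step seen so far, a 1.9-fold lower number from compound 1 to compound 2 (0.27 log units; within the scatter), swapped one small group on that same aromatic carbon without a shift beyond the scatter, so compound 3 is expected to show a step of a 1.1-fold higher number from compound 2 to compound 3 (0.03 log units; within the scatter), again within the scatter. Compound 3 is therefore estimated at 3500 nM, with a range from 1200 nM to 10000 nM.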

Compound 3, concentration for total growth inhibition: 6580 nM
The estimate for compound 3 lay 1.9-fold (0.27 log units) below the measured number; the measured number falls inside the stated range.
By their numbers in this assay, from the lowest: compounds 2, 1 and 3 (each within the scatter of the next).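

In this assay, chloro brings no hydrogen-bond donor or acceptor in place of the hydroxy group, yet the step is a 2.0-fold higher number from compound 2 to compound 3 (0.30 log units; within the scatter). Replacing methoxy with chloro gives a 1.1-fold higher number from compound 1 to compound 3 (0.03 log units; within the scatter), so hydroxy, methoxy and chloro on this aromatic carbon all lie within the scatter of one another. No supporting evidence is available to explain this.

As far as these compounds go, whether an amine, a carboxylic acid or a longer chain such as butoxy on this carbon would move the number beyond the scatter remains open. So does the effect of any change to the shared core.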